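The compounds below may be only part of what the source reports. "The series", "measured", "known", "first", "only" and "open" are said of these compounds alone.

Compounds measured so far in a functional assay on L1210 cells (Mus musculus) for antiproliferative activity; a lower number here means a stronger inhibitor, a higher number a weaker inhibitor:
compound 1 `Cc1nsc2c1nc(SCc1ccccc1)n2[C@H]1C[C@H](O)[C@@H](CO)O1`
compound 2 `Cc1nsc2c1nc(SCc1ccccc1)n2[C@@H]1O[C@H](CO)[C@@H](O)[C@@H]1O`
compound 3 `Cc1nsc2c1ncn2[C@@H]1O[C@H](CO)[C@@H](O)[C@H]1O`

In this assay compound 1 returns only a limit, > 100000 nM. Compound 2 likewise returns only a limit, > 100000 nM. Going by the values given here, compound 3 is the one compound with an actual number, 10000 nM, so it alone gives a fixed point. Among the compounds with values here, the single one-place step among the measured compounds, a step that the two limits leave unreadable from compound 1 to compound 2, has no readable size, since both of its ends sit at the limit.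

Compound 4 `Cc1nsc2c1nc(SCc1ccccc1)n2[C@@H]1O[C@H](CO)[C@@H](O)[C@H]1O` remains to be measured. It differs from compound 3 by benzylsulfanyl in place of hydrogen on an aromatic carbon. Within the data shown here, no measured pair isolates exactly this change. Compounds 1 and 2 both carry the benzylsulfanyl group and both sit at the limit of > 100000 nM in this assay, at which 2 of the 3 values shown sit. Among the measured compounds shown here, compound 3, the one compound without that group, is the one with a number, but its pairs with compound 1 and compound 2 differ in more than one place, so no step can be read from them. The expectation for compound 4 is nevertheless a loss in this assay, with a 10-fold higher number from compound 3 to compound 4 (1.00 log units; beyond the scatter) as the estimated step. Compound 4 is expected near 100000 nM, in the range 15000 nM to 500000 nM, and may well come back as a limit only.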

Compound 4, half-maximal inhibitory concentration: > 100000 nM
Compound 4: a limit, no number; the forecaster's own chance of this, stated with the estimate: 65%; the middle value sits exactly at the limit.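

In this assay, going by these compounds alone, benzylsulfanyl on the aromatic carbon between two ring nitrogen atoms gives an at least 10-fold higher number from compound 3 to compound 4 (1.00 log units; beyond the scatter), the first readable step for this change at this position. Compound 4 gives only a limit, > 100000 nM. Compound 1, compound 2 and compound 4 all carry benzylsulfanyl and all stand at the same limit, so the steps among them cannot be read: the limit of > 100000 nM in this assay, at which 3 of the 4 values shown sit.

As far as these compounds go, whether the loss is particular to benzylsulfanyl or comes with any larger group at this carbon stays open, and an amine or methylsulfanyl at the same place would separate the two. The role of the configuration at the saturated ring carbon also stays open, as the pair that isolates it gives no readable step: the fact that compounds 2 and 4 differ only in the configuration as drawn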